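The source may hold more compounds than are shown below. What is called first, only, known or untested is meant among the compounds shown, and "the series" means these compounds.

Measured in an ADME assay on KB cells (Homo sapiens) for cytotoxicity; on this read-out lower numbers stand for an effect already at smaller amounts and higher numbers for an effect only at larger amounts of compound:
- compound 1 `COC(=O)N1[C@@H]2C=C[C@@](OC)(C(=O)c3c2cc(OC)c(OC)c3OCc2ccc(F)cc2)N1C(=O)OC`: 56.6 ug/mL
- compound 2 `CCCOc1c(OC)c(OC)cc2c1C(=O)[C@]1(OC)C=C[C@H]2N(C(=O)OCC(C)C)N1C(=O)OCC(C)C`: 299 ug/mL

Compound 1 holds the lower of the two numbers in this assay; compound 2 sits a good deal higher, a gap beyond the usual scatter. Compound 3 `COC(=O)N1[C@@H]2C=C[C@@](OC)(C(=O)c3c2cc(OC)c(OC)c3OCc2ccc(Cl)cc2)N1C(=O)OC` is not yet measured. It differs from compound 1 by chloro in place of fluoro on an aromatic carbon. For the measured compounds named here, no pair of measured compounds shows this change, so nothing here sets its size. A small step is expected, toward a somewhat lower number if any, likely not beyond the scatter. Compound 3 is estimated at 45 ug/mL, range 20 ug/mL to 110 ug/mL, the expected step being a 1.3-fold lower number from compound 1 to compound 3 (0.10 log units; within the scatter).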

Compound 3, concentration for half-maximal effect: 55.9 ug/mL
Compound 3: middle estimate off by 1.2-fold (0.09 log units), on the low side; low and high end bracket the measured number.
By their numbers in this assay, from the lowest: compounds 3 and 1 (each within the scatter of the next); then compound 2.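

In this assay, for the compounds shown here, the change from 4-fluorobenzyl to 4-chlorobenzyl on the shared core gives a 1.0-fold lower number from compound 1 to compound 3 (0.01 log units; within the scatter), the only single-place step so far. On this aromatic carbon, para to a large group, chloro and fluoro therefore give values within the scatter of each other. No measured data bear on why the two read alike.

Going by these compounds, whether an amine or a carboxylic acid on this same carbon would shift the read-out remains open. Compound 2 differs from compound 1 in more than one place, so no single change can be read from that pair.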